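The compounds below may be only part of what the source reports. "The series", "measured", "known", "first", "only" and "open" are said of these compounds alone.

Measured so far:
Compound 1 `CC(=O)OCCOCn1cc(/C=C/Br)c(=O)[nH]c1=O`, in a functional assay (Oryctolagus cuniculus) for inhibition (a lower number here means a stronger inhibitor, a higher number a weaker inhibitor), a limit only: > 200 ug/mL.
Compound 2 `Nc1nc2c(nc(I)n2COCCO)c(=O)[nH]1`, in this assay a limit only: >= 350 ug/mL.

Compound 2 thus stands at a limit and not at a number in this assay, and the other value shown is also a limit (the limit of > 200 ug/mL in this assay, at which 1 of the 2 values shown sits, (the limit of >= 350 ug/mL in this assay, at which 1 of the 2 values shown sits)). Among the compounds with values here, no step between measured compounds is available. Compound 3 `CN(C)c1nc2c(=O)[nH]c(N)nc2n1COCCO` differs from compound 2 by dimethylamino in place of iodo on an aromatic carbon. Within the data shown here, with no measured step to anchor the change, no step beyond the scatter is expected in this assay, so the expected step is a number no higher from compound 2 to compound 3 (the limit leaves the size open). For compound 3 the estimate is 350 ug/mL, within 100 ug/mL to 1000 ug/mL, most likely reported again as a limit.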

Compound 3, concentration for 50% inhibition: > 400 ug/mL
Compound 3 was reported as a limit (the forecaster's own chance of this, stated with the estimate: 80%); middle value at least 1.1-fold (0.05 log units) away from the limit.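

Compound 2 and compound 3 both stand at limits in this assay, so no step can be read between them. The compounds shown leave open whether any group on this aromatic carbon gives a measurable inhibition value rather than a limit.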